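The compounds below may be only part of what the source reports. "The series", "measured", "known", "first", "only" and "open" are said of these compounds alone.

Working notes on the acyl variation of the shared core. Compound 3 `CC(C)CC(=O)N[C@@H](C(=O)N1CCC(c2ccc(Cl)cc2)CC1)C(C)C` carries an isobutylcarbonyl on the amide nitrogen; in an assay on THP-1 cells for displacement of a labelled ligand from C-C chemokine receptor type 1 (Homo sapiens) (a higher number here means a weaker inhibitor, a lower number a stronger inhibitor), compound 3 gives 32 nM. Within the data shown here, this is the highest of the three numbers so far, but only nominally: compound 1 `CC(C)CCC(=O)N[C@@H](C(=O)N1CCC(c2ccc(Cl)cc2)CC1)C(C)C` gives 26 nM in this assay, and the step of a 1.2-fold higher number from compound 1 to compound 3 (0.09 log units; within the scatter) lies within the scatter; compound 2 `CC(C)[C@@H](NC(=O)c1cccc(F)c1)C(=O)N1CCC(c2ccc(Cl)cc2)CC1` gives 24 nM, and the step of a 1.3-fold higher number from compound 2 to compound 3 (0.12 log units; within the scatter) is likewise within the scatter. The aryl-for-alkyl swap a 1.1-fold lower number from compound 1 to compound 2 (0.03 log units; within the scatter) also stays within the scatter. All three acyl groups measured so far therefore read as equivalent.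

Compound 4 `CC(C)[C@@H](NC(=O)C1CCCC1)C(=O)N1CCC(c2ccc(Cl)cc2)CC1` differs from compound 3 by cyclopentyl in place of isobutyl on a carbonyl carbon. Among the measured compounds shown here, the steps that bear on this are the three above, each a change of the acyl group at the same carbonyl carbon, and none of them moved this assay beyond the scatter. A cyclopentyl is therefore expected to give no step beyond the scatter either, so a 1.1-fold lower number from compound 3 to compound 4 (0.03 log units; within the scatter) is the expected change. Compound 4 is estimated at 30 nM, within a range of 15 nM to 60 nM.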

Compound 4, half-maximal inhibitory concentration: 70 nM
Estimate against measurement, compound 4: 2.3-fold (0.37 log units) below; the measured number lies above the stated range.
By their numbers in this assay, from the lowest: compounds 2, 1 and 3 (each within the scatter of the next); then compound 4.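

Among these compounds, at this carbonyl carbon the acyl group is not freely interchangeable in this assay: cyclopentyl gives the first steps beyond the scatter, all modest, with a 2.2-fold higher number from compound 3 to compound 4 (0.34 log units; beyond the scatter), a 2.7-fold higher number from compound 1 to compound 4 (0.43 log units; beyond the scatter) and a 2.9-fold higher number from compound 2 to compound 4 (0.46 log units; beyond the scatter). Compound 4 thus stands apart from isobutyl, isopentyl and 3-fluorophenyl, and a ring as such does not set it apart, since compound 2 also carries one at this place and stays within the scatter of compound 1 and compound 3. Nothing measured here accounts for the step.

Open, as far as these compounds go, is whether the higher number belongs to cyclopentyl alone or extends to other saturated carbon rings such as cyclobutyl or cyclohexyl. Also open, from the compounds shown here alone, is how a tert-butyl or a chain ending in an amine would read on the same carbonyl carbon.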